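Halogen swap on the benzyl ring: bromo to chloro

The compounds below may be only part of what the source reports. "The series", "measured", "known", "first", "only" and "open" are said of these compounds alone.

Among the compounds with values here, compound 2 `O=S(=O)(NCCCNCc1ccc(Br)cc1)c1cc(C(F)(F)F)cc(C(F)(F)F)c1` gives the lowest of the two numbers so far in a functional assay on BXPC-3 cells (Homo sapiens) for inhibition, read by MTT assay, with a stated time of 72 h (on this read-out higher numbers stand for weaker inhibition of growth and lower numbers for stronger inhibition of growth), at 1500 nM; compound 1 `O=S(=O)(NCCCNCc1ccc(Cl)c(C(F)(F)F)c1)c1cc(C(F)(F)F)cc(C(F)(F)F)c1` gives 7800 nM, and the step of a 5.2-fold lower number from compound 1 to compound 2 (0.72 log units; beyond the scatter) is the only one measured. Compound 3 `O=S(=O)(NCCCNCc1ccc(Cl)cc1)c1cc(C(F)(F)F)cc(C(F)(F)F)c1` differs from compound 2 by chloro in place of bromo on an aromatic carbon. That single measured step, which also removed a trifluoromethyl, bears on this change only loosely; no direct bromo-to-chloro comparison exists in the series. Little movement beyond the scatter is therefore expected, with compound 3 estimated at 2000 nM (range 800 nM to 5000 nM), a step of a 1.3-fold higher number from compound 2 to compound 3 (0.12 log units; within the scatter).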

Compound 3, concentration for 50% growth inhibition: 1600 nM
Compound 3: the middle estimate sits 1.3-fold (0.10 log units) above what was measured; the measured number falls inside the stated range.
By their numbers in this assay, from the lowest: compounds 2 and 3 (each within the scatter of the next); then compound 1.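

With a 1.1-fold higher number from compound 2 to compound 3 (0.03 log units; within the scatter) in this assay bromo and chloro on this aromatic carbon are not told apart. Within the data shown here, the step of a 4.9-fold lower number from compound 1 to compound 3 (0.69 log units; beyond the scatter) is the first to change trifluoromethyl alone, and it covers the gap between compound 1 and compound 2 with no contribution needed from the halogen. No measurement on hand gives a reason for either step.

Going by these compounds, whether fluoro, iodo or methoxy in this place would stay level with compound 2 and compound 3 remains open. So does the effect of a longer chain in the shared core.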